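Swapping a Chain-End Formyl for Acetoxymethyl

The compounds below may be only part of what the source reports. "The series", "measured", "known", "first", "only" and "open" are said of these compounds alone.

Measured so far in a functional assay on K562 cells (Homo sapiens) for antiproliferative activity (on this read-out higher numbers stand for weaker inhibition of growth and lower numbers for stronger inhibition of growth), are two compounds
- Compound 1 `COC(=O)CCCCCCCCCCCCCC/C=C1\CC(CO)(COC(=O)C(C)(C)C)OC1=O` gives 0.856 ug/mL
- Compound 2 `CC(C)(C)C(=O)OCC1(CO)C/C(=C\CCCCCCCCCCCCCCC=O)C(=O)O1` gives 5.11 ug/mL

Compound 2 has the higher of the two numbers and so the weaker inhibition of growth. Compound 3 `CC(=O)OCCCCCCCCCCCCCCC/C=C1\CC(CO)(COC(=O)C(C)(C)C)OC1=O` is not yet measured. The change acetoxymethyl in place of formyl on a saturated chain carbon, ten or more bonds along the chain from a double-bonded chain carbon puts acetoxymethyl in place of formyl on a saturated chain carbon, ten or more bonds along the chain from a double-bonded chain carbon. Among the measured compounds shown here, the only measured step that bears on this is a 6.0-fold higher number from compound 1 to compound 2 (0.78 log units; beyond the scatter) with hydrogen in place of methoxy on a carbonyl carbon. Compound 1 also has no formyl, so a move back towards its number is expected. The expected step in this assay is a 3.2-fold lower number from compound 2 to compound 3 (0.50 log units; beyond the scatter) with wide uncertainty. Compound 3 is estimated at 1.6 ug/mL (range 0.5 ug/mL to 5 ug/mL).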

Compound 3, concentration for 50% growth inhibition: 0.959 ug/mL
Compound 3: the middle estimate sits 1.7-fold (0.22 log units) above what was measured; measured number inside the range.
By their numbers in this assay, from the lowest: compounds 1 and 3 (each within the scatter of the next); then compound 2.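

Placed on a saturated chain carbon, acetoxymethyl instead of formyl gives a 5.3-fold lower number from compound 2 to compound 3 (0.73 log units; beyond the scatter) in this assay. Acetoxymethyl instead of methoxycarbonyl at that place gives a 1.1-fold higher number from compound 1 to compound 3 (0.05 log units; within the scatter). Two different chain ends therefore read alike, and among these compounds only the formyl of compound 2 stands apart.

No measurement here explains that gap. Going by these compounds, whether a carboxylic acid, an amine or a longer chain would read like compound 3 or like compound 2 remains open.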